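This account rests on a few compounds, and the source may have more. Where it says the series, first, only, none or still open, it means among the compounds named here.

In a functional assay on MCF7 cells (Homo sapiens) for inhibition, read by MTT assay, with a stated time of 3 days (a lower number here means a stronger inhibitor, a higher number a weaker inhibitor), compound 1 (`Cc1cc(=O)oc2cc(OCC(=O)N/N=C/c3ccc([N+](=O)[O-])cc3)ccc12`) gives 5590 nM and compound 2 (`Cc1cc(=O)oc2cc(OCC(=O)N/N=C/c3ccc(F)cc3)ccc12`) gives 9780 nM. Among the measured compounds shown here, compound 2 therefore stands within the scatter of the only other number available. Compound 3 (`Cc1ccc(/C=N/NC(=O)COc2ccc3c(C)cc(=O)oc3c2)o1`) keeps the shared core but carries 5-methylfuran-2-yl in place of 4-fluorophenyl on a carbon with a double bond to nitrogen. For the measured compounds named here, only one measured step bears on this change, a 1.7-fold higher number from compound 1 to compound 2 (0.24 log units; within the scatter), with fluoro in place of nitro on an aromatic carbon, and it stays within the scatter. Going by the values given here, no measured step replaces the whole 4-fluorophenyl, so this is a weak guide, and the range must stay wide. On that evidence, no shift beyond the scatter is expected in this assay. The estimated change is a 1.2-fold lower number from compound 2 to compound 3 (0.09 log units; within the scatter). Compound 3 is expected at 8000 nM, with an estimated range from 2500 nM to 25000 nM.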

Compound 3, half-maximal inhibitory concentration: 3190 nM
The estimate for compound 3 lay 2.5-fold (0.40 log units) above the measured number, within the range that was stated.
By their numbers in this assay, from the lowest: compounds 3, 1 and 2 (each within the scatter of the next, the first and the last beyond it).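

In this assay, among the compounds shown here, replacing the whole aryl group on the carbon with a double bond to nitrogen produces the first change here that clears the scatter: 5-methylfuran-2-yl in place of 4-fluorophenyl gives a 3.1-fold lower number from compound 2 to compound 3 (0.49 log units; beyond the scatter). The same position is therefore not indifferent to its substituent, yet the exchange against 4-nitrophenyl gives only a 1.8-fold lower number from compound 1 to compound 3 (0.24 log units; within the scatter), so the furan separates from the fluorinated ring but not from the nitrated one. Nothing shown explains this shift.

Going by these compounds, it remains open whether the five-membered ring or its methyl group accounts for the step, a question that furan-2-yl without the methyl would address. On these data alone, how a thiophen-2-yl or a pyridin-3-yl group would read at this position also remains open.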